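This account rests on a few compounds, and the source may have more. Where it says the series, first, only, none or still open, it means among the compounds named here.

Series notes, N-type channel block.

Compound 1 `COc1ccc(COC(=O)[C@@H](N)CSCC2CCCCC2)cc1` is the free amine of the series and in an assay on IMR-32 cells for inhibition of Voltage-dependent N-type calcium channel subunit alpha-1B (Homo sapiens) (a lower number here means a stronger inhibitor, a higher number a weaker inhibitor), compound 1 gives 5800 nM. Compound 2 `COc1ccc(COC(=O)[C@H](CSCC2CCCCC2)NC(=O)[C@@H]2CSCN2)cc1` carries a (1,3-thiazolidin-4-yl)carbonyl on that amine nitrogen; in this assay compound 2 gives 2700 nM. Among the compounds with values here, the step of a 2.1-fold lower number from compound 1 to compound 2 (0.33 log units; beyond the scatter) is the only single-point change measured so far. Within the data shown here, compound 3 `O=C(N[C@@H](CSCC1CCCCC1)C(=O)NCc1ccc(Oc2ccccc2)cc1)[C@@H]1CSCN1` keeps the acyl group of compound 2 but differs from it in more than one place, and in this assay compound 3 gives 290 nM; no single step can be drawn from it. On the three numbers compound 2 stands second highest, between compound 1 and compound 3.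

Compound 4 `COc1ccc(COC(=O)[C@H](CSCC2CCCCC2)NC(=O)[C@@H]2CCCN2C(=O)OC(C)(C)C)cc1` is to be measured. Relative to compound 2 the change is 1-(tert-butoxycarbonyl)pyrrolidin-2-yl in place of 1,3-thiazolidin-4-yl on a carbonyl carbon. Among the measured compounds shown here, no measured step touches this acyl group directly; the one measured step shows only that acylating the amine nitrogen of compound 1 with a thiazolidinyl carbonyl gives a modest gain, and nothing measured tells how exchanging that acyl group for another behaves. For the measured compounds named here, with no bearing step, no change beyond the scatter is expected in this assay from compound 2 to compound 4, and the step is estimated as a 1.1-fold higher number from compound 2 to compound 4 (0.05 log units; within the scatter). For compound 4 the expected value in this assay is 3000 nM, with a range from 1000 nM to 9000 nM.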

Compound 4, half-maximal inhibitory concentration: 880 nM
Estimate against measurement, compound 4: 3.4-fold (0.53 log units) above, and the stated range ends above it.
By their numbers in this assay, from the lowest: compound 3; then compound 4; then compound 2; then compound 1.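

Exchanging the acyl group at this position is not neutral: on a carbonyl carbon whose other neighbour is an amide-type nitrogen, 1-(tert-butoxycarbonyl)pyrrolidin-2-yl in place of 1,3-thiazolidin-4-yl gives a 3.1-fold lower number from compound 2 to compound 4 (0.49 log units; beyond the scatter) in this assay. Within the data shown here, this is the first measured exchange of one acyl group for another, and it shows that a much larger group, with 12 heavy atoms instead of 5 and no hydrogen-bond donor, is accepted here with a modest gain rather than a loss. Nothing available explains the gain, so it stands as an observation only.

The change replaces the ring and adds the tert-butoxycarbonyl group together, so the compounds shown cannot separate their contributions; the unsubstituted pyrrolidin-2-yl with its free ring amine, or the same ring with a simple acetyl group on its nitrogen, would bear on that. From the compounds shown here alone, it also remains open whether the gain from this acyl group would carry over to the 4-phenoxybenzyl amide of compound 3, which differs from compound 4 in more than one place.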